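Methyl to Benzyl Ester on a Thiophene-Bearing Core

The source may report more compounds than this note shows. Statements on the series, on what has been measured and on what is new or still open speak of the compounds shown alone.

Of the compounds shown here, two sharing one core have been tested in an assay on membranes from HEK293 cells for displacement of a labelled ligand from adenosine receptor A2b (Homo sapiens), read by scintillation counting, with a stated time of 30 min, tested at 1 uM; a higher number here means more inhibition at the concentration tested (going by the name of the read-out), a lower number less inhibition. Compound 1, `CC1=C(C(=O)OCc2ccccc2)C(c2cccs2)NC(=S)N1`, gives 45% in this assay. Compound 2, `COC(=O)C1=C(C)NC(=S)NC1c1ccsc1`, gives 38% in this assay. Compound 2 holds the lower of the two numbers, yet the gap to compound 1 falls within the usual scatter, so the two cannot be told apart on these data.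

Compound 3, `CC1=C(C(=O)OCc2ccccc2)C(c2ccsc2)NC(=S)N1`, has not yet been measured. It differs from compound 2 by one change: phenyl in place of hydrogen on a saturated chain carbon bound to an oxygen next to a carbonyl group. Compound 1 already carries this benzyl ester, though on a core with the thiophene attached through a different carbon, and compound 1 gives 45% in this assay, a number that does not stand apart from compound 2.

Within the data shown here, no pair of measured compounds differs in this one place alone, so there is no measured step to lean on. The step from compound 2 to compound 3 is expected to be small, a number 6 percentage points higher from compound 2 to compound 3 (within the scatter), in no direction that goes beyond the scatter. Compound 3 is therefore estimated at 44% in this assay, with a likely range from 25% to 63%.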

Compound 3, a percentage reported as inhibition, at one concentration (the size of the read-out at that concentration, not a potency): 10%
The estimate for compound 3 lay 34 percentage points above the measured number; measured number below the stated range.
By their numbers in this assay, from the lowest: compound 3; then compounds 2 and 1 (each within the scatter of the next).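

Going from methyl to benzyl in this assay gives a number 28 percentage points lower from compound 2 to compound 3 (beyond the scatter), so at this saturated chain carbon bound to an oxygen next to a carbonyl group, adding a phenyl in place of hydrogen is not a neutral change when the thiophene is thiophen-3-yl. With the benzyl ester held in place, thiophen-3-yl in place of thiophen-2-yl on a saturated ring carbon gives a number 35 percentage points lower from compound 1 to compound 3 (beyond the scatter), which shows that the point of attachment of the thiophene matters as well, although the ring itself keeps the same atoms. Among these compounds, neither feature alone goes with the low number, since compound 1 carries the benzyl ester, compound 2 carries the thiophen-3-yl group, and only compound 3 carries both.

Still open, as far as these compounds go, is whether a longer chain such as an ethyl or propyl ester, or a carboxylic acid at the same place, would behave like the methyl ester or like the benzyl ester on each thiophene. The data shown offer no measurement that explains either step.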